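Adding a second isopropyl ester to the core acid

The compounds below may be only part of what the source reports. "The series", "measured", "known", "first", "only" and "open" are said of these compounds alone.

Compound 3 `CC(C)OC(=O)c1cccc(NC(=O)[C@@H]2C[C@H](SC3=C(C(=O)O)N4C(=O)[C@H]([C@@H](C)O)[C@H]4[C@H]3C)CN2)c1` is the starting point. In an ADME assay for metabolic stability, read by LC-MS, with a stated time of 3 h, at pH 6.5, tested at 50 uM (on this read-out lower numbers stand for a less stable compound and higher numbers for a more stable compound), compound 3 gives > 95%, which is a limit of the assay rather than a number. Compound 1 `Cc1oc(=O)oc1COC(=O)c1cccc(NC(=O)[C@@H]2C[C@H](SC3=C(C(=O)O)N4C(=O)[C@H]([C@@H](C)O)[C@H]4[C@H]3C)CN2)c1` also stands at a limit, > 95%. Compound 2 `C[C@@H](O)[C@H]1C(=O)N2C(C(=O)OCC(F)(F)F)=C(S[C@@H]3CN[C@H](C(=O)Nc4cccc(C(=O)O)c4)C3)[C@H](C)[C@H]12` likewise stands at a limit, > 95%. Among the measured compounds shown here, the one measured step touching compound 3, a step that the two limits leave unreadable from compound 1 to compound 3, cannot be sized because of the limit of > 95% in this assay, at which 3 of the 3 values shown sit. Compound 4 `CC(C)OC(=O)C1=C(S[C@@H]2CN[C@H](C(=O)Nc3cccc(C(=O)OC(C)C)c3)C2)[C@H](C)[C@@H]2[C@@H]([C@@H](C)O)C(=O)N12` differs from compound 3 by isopropyl in place of hydrogen on an oxygen next to a carbonyl group. For the measured compounds named here, since every measured value sits at the limit, no step offers a scale for this change, and the only guidance is that all three measured compounds are highly stable. For compound 4 a value near the limit is therefore expected, 90%, within 60% to 99%. The step this expectation implies is a number at least 5 percentage points lower from compound 3 to compound 4 (that floor lies within the scatter).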

Compound 4, percent of the compound remaining: > 95%
Compound 4: only a limit was reported; the forecaster's own chance of this, stated with the estimate: 50%; middle value at least 5 percentage points away from the limit.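

No step can be read from compound 3 to compound 4 in this assay, as both values are limits: the limit of > 95% in this assay, at which 4 of the 4 values shown sit.

Whether isopropyl in place of hydrogen on an oxygen next to a carbonyl group changes the percent remaining at all stays open, with no compound shown giving a value short of the limit.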